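Swapping Ethoxy for Trifluoromethyl: What to Expect

The compounds below may be only part of what the source reports. "The series", "measured", "known", "first", "only" and "open" are said of these compounds alone.

Three measured compounds share one core and differ in a single group on it. In a functional assay on Hep 3B2 cells (Homo sapiens) for antiproliferative activity, read by MTT assay, with a stated time of 24 h, tested at 100 ug/mL (on this read-out higher numbers stand for a stronger effect at the one concentration tested and lower numbers for a weaker effect), compound 1 `Cc1ccc2nc(C(=O)Nc3c(F)cc(-c4cccc(F)c4)cc3F)c(C)c(O)c2c1` gives 68.3% and compound 2 `Cc1c(C(=O)Nc2c(F)cc(-c3cccc(F)c3)cc2F)nc2ccc(F)cc2c1O` gives 75.2%, with a number 6.9 percentage points higher from compound 1 to compound 2 (within the scatter). Compound 3 `CCOc1ccc2nc(C(=O)Nc3c(F)cc(-c4cccc(F)c4)cc3F)c(C)c(O)c2c1` gives 33.3%, the lowest of the three, reached by a number 35 percentage points lower from compound 1 to compound 3 (beyond the scatter) and by a number 41.9 percentage points lower from compound 2 to compound 3 (beyond the scatter). Compound 4 `Cc1c(C(=O)Nc2c(F)cc(-c3cccc(F)c3)cc2F)nc2ccc(C(F)(F)F)cc2c1O` is not yet measured; it differs from compound 3 by trifluoromethyl in place of ethoxy on an aromatic carbon. Going by the values given here, because a number 35 percentage points lower from compound 1 to compound 3 (beyond the scatter) and a number 41.9 percentage points lower from compound 2 to compound 3 (beyond the scatter) were both large falls when ethoxy entered, removing ethoxy is expected to recover much of that loss, although trifluoromethyl itself has no measured precedent here. Compound 4 is therefore estimated at 60%, within 35% to 80%, an expected a number 26.7 percentage points higher from compound 3 to compound 4 (beyond the scatter).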

Compound 4, a percentage reported as inhibition, at one concentration (the size of the read-out at that concentration, not a potency): 68.4%
Compound 4: middle estimate off by 8.4 percentage points, on the low side; measured number inside the range.
By their numbers in this assay, from the lowest: compound 3; then compounds 1, 4 and 2 (each within the scatter of the next).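

In this assay, trifluoromethyl at this position removes the fall seen with ethoxy (a number 35.1 percentage points higher from compound 3 to compound 4 (beyond the scatter)). Trifluoromethyl has more heavy atoms than ethoxy, yet compound 4 stands level with the smaller-looking methyl and fluoro compounds (a number 0.1 percentage points higher from compound 1 to compound 4 (within the scatter); a number 6.8 percentage points lower from compound 2 to compound 4 (within the scatter)), so heavy-atom count alone does not set the number here. Nothing measured explains why ethoxy stands apart.

Still open, from the compounds shown here alone, is whether the fall belongs to ethoxy alone or extends to other oxygen-linked groups, such as methoxy or the longer propoxy. Going by these compounds, how an amine or a carboxylic acid would behave at this position also remains unknown.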